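The source may hold more compounds than are shown below. What is called first, only, known or untested is meant among the compounds shown, and "the series" means these compounds.

The three measured compounds share one core and differ in the side groups around it. Compound 1 `COc1cc(C=c2s/c(=C3\C(=O)Nc4ccc(F)cc43)n(CCN(C)C)c2=O)cc(OC)c1OC` in a functional assay on NCI-H460 cells (Homo sapiens) for inhibition, read by MTT assay, with a stated time of 72 h (on this read-out higher numbers stand for weaker inhibition and lower numbers for stronger inhibition), gives 1700 nM. Compound 2 `CCN(CC)CCCn1c(=O)c(=Cc2ccc(F)cc2F)s/c1=C1\C(=O)Nc2ccc(Cl)cc21` in this assay gives 6100 nM. Compound 3 `CN(C)CCn1c(=O)c(=Cc2ccc(O)cc2)s/c1=C1\C(=O)Nc2ccc(Cl)cc21` in this assay gives 2030 nM. On these numbers compound 3 stands second highest of the three: its number and that of compound 1 lie within the scatter of each other, so no order between them can be read, whereas the number of compound 2 lies beyond the scatter and is the higher of the two.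

Compound 4 `CN(C)CCn1c(=O)c(=Cc2ccc(O)cc2)s/c1=C1\C(=O)Nc2ccc(Br)cc21` differs from compound 3 in a single place: bromo in place of chloro on an aromatic carbon. Among the compounds with values here, no measured pair in this set shows this exchange, so its effect cannot be read from the data; it is an exchange of one halogen for another at the same place, and nothing else moves. In this assay the expected step is a 1.0-fold lower number from compound 3 to compound 4 (0.01 log units; within the scatter), small, in no set direction, and within the scatter. Compound 4 is estimated at 2000 nM in this assay, with a range from 1000 nM to 4000 nM.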

Compound 4, half-maximal inhibitory concentration: 1110 nM
For compound 4 the middle estimate is 1.8-fold (0.26 log units) above the measured one; low and high end bracket the measured number.
By their numbers in this assay, from the lowest: compounds 4, 1 and 3 (each within the scatter of the next); then compound 2.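

Within the data shown here, this is the first pair in the set that differs in one place only, so it gives the first direct reading of a change at this position, on an aromatic carbon of a six-membered aromatic ring of carbon only, part of a fused system of two rings. In this assay, bromo in place of chloro gives a 1.8-fold lower number from compound 3 to compound 4 (0.26 log units; within the scatter), so on this read-out the two halogens cannot be told apart at this place, with the rest of the structure held the same. The data hold nothing that speaks to what lies behind this step.

As far as these compounds go, the pair covers only these two halogens, and only alongside the dimethylaminoethyl chain and the hydroxyphenyl side group shared by compound 3 and compound 4, so whether the step would read the same with other side groups stays open. From the compounds shown here alone, compound 1 and compound 2 differ from them in more than one place and cannot settle this, and what a nitrile, an amine or a carboxylic acid at this position would do also remains open.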